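From tert-butyl to isopropyl: a one-carbon trim

This account rests on a few compounds, and the source may have more. Where it says the series, first, only, none or still open, it means among the compounds named here.

Measured so far in a functional assay on the whole organism (strain Swiss albino) for inhibition, with Mus musculus as the target, read by paw edema, with stated times of 30 min and 360 min, at a dose of 100 mg/kg by the subcutaneous route; on this read-out lower numbers stand for less inhibition and higher numbers for more inhibition at the one dose given (going by the name of the read-out):
compound 1 `CCOC(=O)C1CCN(C(=O)c2cc(-c3ccc(C)cc3)nn2Cc2ccccc2)CC1` gives 57.6%
compound 2 `Cc1ccc(-c2cc(C(=O)NCc3cccnc3)n(Cc3ccccc3)n2)cc1` gives 25.3%
compound 3 `Cc1ccc(-c2cc(C(=O)Oc3ccc(C(C)(C)C)cc3)n(Cc3ccccc3)n2)cc1` gives 62%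

Compound 3 and compound 1 lie within the scatter of each other, so nothing separates them; compound 2 sits beyond the scatter below both. Compound 4 `Cc1ccc(-c2cc(C(=O)Oc3ccc(C(C)C)cc3)n(Cc3ccccc3)n2)cc1` is not yet measured. It differs from compound 3 by one small change: hydrogen in place of methyl on a saturated chain carbon bound to an aromatic carbon and two saturated chain carbons. Going by the values given here, no measured pair here shows what such a trim does, so the step of a number 4 percentage points lower from compound 3 to compound 4 (within the scatter) is expected to be small, in either direction, and not beyond the scatter. Compound 4 is therefore estimated at 58%, with a likely range from 44% to 70%.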

Compound 4, a percentage reported as inhibition, in the whole organism at one dose (the size of the read-out at that dose, not a potency): 31.5%
Beside the measured number, compound 4's estimate is 26.5 percentage points above it; measured number outside the range, below it.
By their numbers in this assay, from the lowest: compounds 2 and 4 (each within the scatter of the next); then compounds 1 and 3 (each within the scatter of the next).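

In this assay, one methyl on this saturated chain carbon proves to matter: cutting tert-butyl to isopropyl gives a number 30.5 percentage points lower from compound 3 to compound 4 (beyond the scatter), so a single carbon can decide the read-out here. Putting 4-isopropylphenoxy in place of ((pyridin-3-yl)methyl)amino on the carbonyl carbon gives a number 6.2 percentage points higher from compound 2 to compound 4 (within the scatter), so these two very different groups are not told apart by this measurement. Nothing available explains the loss on trimming. As far as these compounds go, how an ethyl or cyclopropyl group in place of the tert-butyl would read remains open, as does whether the same trim matters with a different group on the carbonyl carbon.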